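Chloro to methyl on the fused ring: permeability notes

This account rests on a few compounds, and the source may have more. Where it says the series, first, only, none or still open, it means among the compounds named here.

Compound 1 `CC(C)Nc1nc(NCc2ccco2)c2cccc(Cl)c2n1` and compound 2 `CC(C)Nc1nc(NCc2ccco2)c2c(Cl)cccc2n1` are built from the same atoms joined differently; the difference between the two cores is not broken down here. In a physicochemical assay for permeability, using PAMPA, at pH 4 (a lower number here means that the compound crosses the layer more slowly, a higher number that the compound crosses the layer faster), compound 1 gives 67.6 10^-6 cm/s, while compound 2 gives 169 10^-6 cm/s, the highest of the three measured numbers and beyond the scatter from both others. Compound 3 `Cc1cccc2c(NCc3ccco3)nc(NC(C)C)nc12` differs from compound 1 by methyl in place of chloro on an aromatic carbon; in this assay compound 3 gives 45.9 10^-6 cm/s, a step of a 1.5-fold lower number from compound 1 to compound 3 (0.17 log units; within the scatter).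

Compound 4 `Cc1cccc2nc(NC(C)C)nc(NCc3ccco3)c12` remains to be measured. It differs from compound 2 by methyl in place of chloro on an aromatic carbon, the same change that separates compound 1 from compound 3, with the place described in the same words in both pairs. Within the data shown here, only one earlier instance of this change exists, and that step fell within the scatter, so a step of a 1.4-fold lower number from compound 2 to compound 4 (0.15 log units; within the scatter) is expected, resting on a 1.5-fold lower number from compound 1 to compound 3 (0.17 log units; within the scatter) alone. On that basis compound 4 is estimated at 120 10^-6 cm/s, with an expected range from 60 10^-6 cm/s to 240 10^-6 cm/s.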

Compound 4, apparent permeability: 45.9 10^-6 cm/s
Estimate against measurement, compound 4: 2.6-fold (0.42 log units) above; the measured number lies below the stated range.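

In this assay, methyl in place of chloro on an aromatic carbon gives a step of a 3.7-fold lower number from compound 2 to compound 4 (0.57 log units; beyond the scatter) on the core of compound 2, beyond the scatter, while the same change on the core of compound 1 gives a 1.5-fold lower number from compound 1 to compound 3 (0.17 log units; within the scatter) and stays within the scatter. Among these compounds, the size of the step therefore did not carry from one core to the other, which shows that the single earlier pair was a poor guide here, but two pairs set no rule for any other core. Nothing available bears on why the two steps differ, and the difference stays unexplained.

The compounds shown hold only chloro or methyl on this aromatic carbon, so the behaviour of a fluoro group, a methoxy group or an amine there remains open. As far as these compounds go, whether any of these would track the step seen on the core of compound 1 or the one seen on the core of compound 2 also remains open.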